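The source may hold more compounds than are shown below. What is called first, only, known or untested is meant among the compounds shown, and "the series" means these compounds.

The measured compounds in a functional assay on Sf9 cells for antagonist activity at histamine H2 receptor (Homo sapiens), read by scintillation counting and GTPgammaS binding, with a stated time of 90 min (a lower number here means a less potent compound, a higher number a more potent compound, by a factor of ten per unit of this negative logarithm), are few. Compound 1 `Cc1nc(CCCN/C(=N\C#N)NCCSc2ccccc2)c[nH]1` gives only a limit, < 5. Compound 2 `Cc1nccn1CCCCCN/C(=N\C#N)NCCSc1ccccc1` likewise gives only a limit, < 5. Compound 3 `N#C/N=C(\NCCCCc1nc(N)n[nH]1)NCCSc1ccccc1` also gives only a limit, < 5.

Compound 1 therefore stands nowhere definite in this assay: its value is a limit, not a number, and the same holds for the other two, as the limit of < 5 in this assay, at which 3 of the 3 values shown sit, records. The unmeasured compound 4 `N#C/N=C(\NCCCNc1nc(N)n[nH]1)NCCSc1ccccc1` differs from compound 1 by (3-amino-1H-1,2,4-triazol-5-yl)amino in place of 2-methyl-1H-imidazol-4-yl on a saturated chain carbon, three bonds along the chain from an amine nitrogen. Within the data shown here, the steps that bear on this change are a step that the two limits leave unreadable from compound 1 to compound 3, which installs a related 3-amino-1H-1,2,4-triazol-5-yl group, and a step that the two limits leave unreadable from compound 1 to compound 2 and a step that the two limits leave unreadable from compound 2 to compound 3; none of them can be sized, since both ends sit at the limit. No direction beyond the scatter can be read from them. Compound 4 is therefore expected to remain near the limit as well, with an expected step that the limit leaves unreadable from compound 1 to compound 4. The estimate for compound 4 in this assay is 4.7, within 4 to 5.5.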

Compound 4, negative logarithm of the antagonist equilibrium constant: < 5
Compound 4: no number, only a limit; the forecaster's own chance of this, stated with the estimate: 70%; the middle value is on the limit's open side.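

Compound 4 gives only a limit, < 5. Among these compounds, no step from compound 4 to compound 1, compound 2 or compound 3 can be read in this assay: the limit of < 5 in this assay, at which 4 of the 4 values shown sit. The compounds shown leave open whether these groups differ at all in antagonist potency.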